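The source may hold more compounds than are shown below. What is called first, only, known or untested is meant among the compounds shown, and "the series" means these compounds.

Measured so far:
Compound 1 `Cc1ccc2c(c1)CCN2S(=O)(=O)c1ccc(-c2cnc(C3CC3)o2)cc1` gives 91.1%.
Compound 2 `O=[N+]([O-])c1ccc2c(c1)N(S(=O)(=O)c1ccc(-c3cnc(C4CC4)o3)cc1)CC2` gives 96.7%.

In a functional assay on Jurkat cells (Homo sapiens) for inhibition, read by MTT assay, tested at 10 uM (a lower number here means less inhibition, a higher number more inhibition at the concentration tested (going by the name of the read-out)), compound 2 gives 96.7%, the higher of the two numbers, yet compound 1 with 91.1% lies within the usual scatter of it, so the two cannot be told apart. Compound 3 `O=S(=O)(c1ccc(-c2cnc(C3CC3)o2)cc1)N1CCc2ccc(Cl)cc21` has not been measured yet. It differs from compound 2 in one place: chloro in place of nitro on an aromatic carbon. Among the measured compounds shown here, no step between measured compounds exists to guide the size of this change, so in this assay I expect none beyond the scatter. Compound 3 is therefore estimated at 92%, between 78% and 99%, which means an expected step of a number 4.7 percentage points lower from compound 2 to compound 3 (within the scatter).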

Compound 3, a percentage reported as inhibition, at one concentration (the size of the read-out at that concentration, not a potency): 95.5%
The estimate for compound 3 lay 3.5 percentage points below the measured number, and the stated range covers the measured number.
By their numbers in this assay, from the lowest: compounds 1, 3 and 2 (each within the scatter of the next).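

With chloro in place of nitro on this aromatic carbon, this assay shows a number 1.2 percentage points lower from compound 2 to compound 3 (within the scatter) and so does not tell the two groups apart. Among the compounds shown here, this is the first one-place comparison at this position, and it shows that inhibition at the tested concentration is kept with either group. No measured property is available to explain this result.

Going by these compounds, whether an amine or a carboxylic acid on this carbon would keep inhibition remains open. A reading at one concentration also gives no potency for any of these compounds.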